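Swapping the Aryl Group on a Weakly Active Core

The compounds below may be only part of what the source reports. "The series", "measured", "known", "first", "only" and "open" are said of these compounds alone.

compound 1, `COc1cc(C2=NN(C(C)=O)C(c3cccc(OC)c3OC)O2)cc(OC)c1OC`: 17.5%
compound 2, `COc1cc(C(=O)N/N=C/c2ccc(F)cc2)cc(OC)c1OC`: 61.1%

In a functional assay on BGC-823 cells (Homo sapiens) for antiproliferative activity, read by MTT assay, tested at 5 uM (a higher number here means a stronger effect of the compound at the concentration tested, a lower number a weaker effect), compound 1 gives 17.5%, the lowest of the two numbers. Compound 2 gives 61.1%, a number higher by more than the usual scatter. Among the compounds with values here, no step between measured compounds that differ in one place is available, so the effect of a single change on this core is not yet known. Compound 3, `COc1cc(C2=NN(C(C)=O)C(c3cccc(C(F)(F)F)c3)O2)cc(OC)c1OC`, differs from compound 1 by 3-(trifluoromethyl)phenyl in place of 2,3-dimethoxyphenyl on a saturated ring carbon. This change is expected to shift this assay only modestly upward, as a number 8.5 percentage points higher from compound 1 to compound 3 (within the scatter). Compound 3 is estimated at 26%, between 8% and 50%.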

Compound 3, a percentage reported as inhibition, at one concentration (the size of the read-out at that concentration, not a potency): 41.1%
Compound 3: the middle estimate sits 15.1 percentage points below what was measured; low and high end bracket the measured number.
By their numbers in this assay, from the lowest: compound 1; then compound 3; then compound 2.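

On the saturated ring carbon of the shared core, the aryl group is a place where a single change can move the read-out. In this assay, within the data shown here, the swap of 2,3-dimethoxyphenyl for 3-(trifluoromethyl)phenyl gives a number 23.6 percentage points higher from compound 1 to compound 3 (beyond the scatter) and is the first one-place step on this core that can be read. Nothing measured here accounts for this step. Still open, going by these compounds, is whether the trifluoromethyl group itself or the loss of the methoxy groups carries the step, and how an unsubstituted phenyl, or a phenyl bearing an amine or a carboxylic acid, would read at this carbon.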